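Trimming the dibromoethenyl chain of compound 2 to a vinyl

This account rests on a few compounds, and the source may have more. Where it says the series, first, only, none or still open, it means among the compounds named here.

Measured so far:
- compound 1, `C[C@H]1CC(Cl)=C[C@@H](C2CCCCC2)O1`: 65000 nM
- compound 2, `C[C@@H]1O[C@H](CCC=C(Br)Br)C([Si](C)(C)C)=C(Cl)[C@H]1C`: 25000 nM

In a functional assay on WiDr cells (Homo sapiens) for antiproliferative activity (a lower number here means a stronger inhibitor of growth, a higher number a weaker inhibitor of growth), compound 1 gives 65000 nM. In this assay compound 2 gives 25000 nM. Compound 2 thus holds the lower of the two numbers, and the gap to compound 1 lies beyond the usual scatter of such measurements. The two compounds share a saturated oxygen-containing core but differ in several places at once, so nothing can be read from them about any single change.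

Compound 3, `C=CCC[C@H]1O[C@@H](C)[C@H](C)C(Cl)=C1[Si](C)(C)C`, is the next one to be tested. It differs from compound 2 in one place: vinyl in place of 2,2-dibromoethenyl on a saturated chain carbon, two bonds along the chain from a saturated ring carbon. Going by the values given here, nothing measured so far shows what removing the two bromines does here. Both measured compounds are weak growth inhibitors, and the expectation is that compound 3 stays in that range. The step from compound 2 to compound 3 is expected to be small, a 1.4-fold higher number from compound 2 to compound 3 (0.15 log units; within the scatter), and most likely within the scatter. Compound 3 is estimated at 35000 nM, within a range from 12000 nM to 100000 nM.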

Compound 3, concentration for 50% growth inhibition: 37000 nM
Compound 3: middle estimate off by 1.1-fold (0.02 log units), on the low side, and the stated range covers the measured number.
By their numbers in this assay, from the lowest: compounds 2, 3 and 1 (each within the scatter of the next, the first and the last beyond it).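

In this assay, vinyl in place of 2,2-dibromoethenyl on a saturated chain carbon, two bonds along the chain from a saturated ring carbon, gives a 1.5-fold higher number from compound 2 to compound 3 (0.17 log units; within the scatter) and so leaves compound 2 and compound 3 indistinguishable in this read-out. Going by these compounds alone, this is the first single change that can be read in this set, and it shows that this position accepts the loss of both bromines, and with them two of the four heavy atoms of the group, without a difference that the measurement can resolve, while both compounds stay weak growth inhibitors. Nothing measured here explains this result or ties it to any property of either group.

From the compounds shown here alone, what an amine, a carboxylic acid or a phenyl ring would do at this position remains open, as does the effect of a longer chain carrying the vinyl. Also open, going by these compounds, is whether any change elsewhere on the shared core, such as replacing the chlorine, could bring a stronger inhibition of growth than these compounds show.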